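This account rests on a few compounds, and the source may have more. Where it says the series, first, only, none or still open, it means among the compounds named here.

Measured in a functional assay on A549 cells (Homo sapiens) for cytotoxicity, read by MTT assay; a lower number here means a stronger inhibitor, a higher number a weaker inhibitor:

- Compound 1 `CC1=CCC23OC(C(C)(C)O)(CC12O)C(=O)C=C3C`: > 10000 nM
- Compound 2 `CC(C)[C@]1(O)C(=O)C[C@H](C)[C@@]12CC[C@](C)(O)C(=O)C2`: > 10000 nM
- Compound 3 `CC1=C[C@H](O)[C@]2(CC1=O)[C@H](C)CC(=O)[C@H]2C(C)C`: > 10000 nM

Each of these entries is a limit of the assay and not a number. In this assay compound 3 gives > 10000 nM, and this too is only a limit. It has no company other than the limit of > 10000 nM in this assay, at which 3 of the 3 values shown sit, so the measured set offers no graded value against which compound 3 could be ranked.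

Compound 4 `CC1=C[C@@H](O)[C@@]2(CC1=O)[C@@H](C(C)C)C(=O)C[C@@H]2C` has not yet been measured. It is a stereoisomer of compound 3: the two compounds have the same atoms and bonds and differ only in configuration as drawn: 3 of 4 stereo elements differ; a stereocentre at a saturated ring carbon is drawn S in compound 3 and R in compound 4; a stereocentre at a saturated ring carbon is drawn S in compound 3 and R in compound 4; a stereocentre at a saturated ring carbon is drawn R in compound 3 and S in compound 4. Nothing leaves and nothing enters, and the change lies only in how the saturated ring carbons are drawn. Going by the values given here, no measured pair shows what such a change does here, so the expectation rests on (the limit of > 10000 nM in this assay, at which 3 of the 3 values shown sit). An estimated step that the limit leaves unreadable from compound 3 to compound 4 is expected, with no change beyond the scatter, and a further limit is the likeliest report.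

For compound 4 the expected value is 20000 nM, with an estimated range from 8000 nM to 60000 nM.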

Compound 4, half-maximal inhibitory concentration: > 10000 nM
Compound 4: only a limit was reported; the forecaster's own chance of this, stated with the estimate: 90%; the middle value is on the limit's open side.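

In this assay, compound 3 and compound 4 are both reported only as limits, so no step can be read between these two stereoisomers. The compounds shown leave open how configuration bears on this read-out, and they offer no graded value: the limit of > 10000 nM in this assay, at which 4 of the 4 values shown sit.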